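Allyl ether variation in a bromo-substituted analogue

This account rests on a few compounds, and the source may have more. Where it says the series, first, only, none or still open, it means among the compounds named here.

Measured compounds:
Compound 1 `C=CCOc1c(C)c(C)c2c(c1C)CCC(C)(COc1ccc(/C=C3\SC(=O)NC3=O)cc1)O2` gives 42% in a functional assay on MCF7 cells (Homo sapiens), tested at 5 uM; a higher number here means a weaker effect of the compound at the concentration tested, a lower number a stronger effect.
Compound 2 `CC(C)=CCOc1c(C)c(C)c2c(c1C)CCC(C)(COc1ccc(/C=C3\SC(=O)NC3=O)cc1)O2` gives 21% in this assay.
Compound 3 `C=CCOc1c(C)c(C)c2c(c1C)CCC(C)(COc1ccc(/C=C3\SC(=O)NC3=O)cc1Br)O2` gives 98% in this assay.

Compound 3 stands highest of the three in this assay, with compound 1 nearest and compound 2 furthest. The difference between compound 1 and compound 3 is bromo in place of hydrogen on an aromatic carbon, and that step in this assay reads a number 56 percentage points higher from compound 1 to compound 3 (beyond the scatter). The difference between compound 1 and compound 2 is 2-methylprop-1-en-1-yl in place of vinyl on a saturated chain carbon bound to an oxygen on an aromatic ring, and the matching step in this assay reads a number 21 percentage points lower from compound 1 to compound 2 (beyond the scatter).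

Compound 4 `CC(C)=CCOc1c(C)c(C)c2c(c1C)CCC(C)(COc1ccc(/C=C3\SC(=O)NC3=O)cc1Br)O2` has not been measured. It differs from compound 3 by 2-methylprop-1-en-1-yl in place of vinyl on a saturated chain carbon bound to an oxygen on an aromatic ring; the place is worded the same as for the change from compound 1 to compound 2, so this is the same change applied to the bromo-bearing core of compound 3 rather than to the core of compound 1. For the measured compounds named here, whether the step carries over to this core is not known from the three measured compounds; the only direct precedent is the single pair 1 to 2.

Compound 4 is expected to give a step of a number 13 percentage points lower from compound 3 to compound 4 (beyond the scatter) in this assay, a somewhat smaller move than the earlier one, resting on a number 21 percentage points lower from compound 1 to compound 2 (beyond the scatter) seen for compound 1 and on compound 3 sitting at 98%, which leaves little room for a higher number. Compound 4 is accordingly estimated at 85%, with a range from 62% to 102%.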

Compound 4, a percentage reported as activity, at one concentration (the size of the read-out at that concentration, not a potency): 84%
Compound 4: the middle estimate sits 1 percentage points above what was measured, and the stated range covers the measured number.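

On the bromo-bearing core, 2-methylprop-1-en-1-yl in place of vinyl, which turns allyloxy into (3-methylbut-2-en-1-yl)oxy, reads a number 14 percentage points lower from compound 3 to compound 4 (beyond the scatter) in this assay, and the change carries over from the core of compound 1 with no difference in size beyond the scatter: the same change on two cores in this assay, a number 21 percentage points lower (beyond the scatter) from compound 1 to compound 2 and a number 14 percentage points lower (beyond the scatter) from compound 3 to compound 4, 7 percentage points apart, within the scatter of two such steps
Bromo in place of hydrogen on an aromatic carbon, read on the (3-methylbut-2-en-1-yl)oxy compounds, gives a number 63 percentage points higher from compound 2 to compound 4 (beyond the scatter), and this change also carries over between the two cores: the same change on two cores in this assay, a number 56 percentage points higher (beyond the scatter) from compound 1 to compound 3 and a number 63 percentage points higher (beyond the scatter) from compound 2 to compound 4, 7 percentage points apart, within the scatter of two such steps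
Within these four compounds the two changes therefore act about independently of each other, but this rests on one set of four at a single concentration, so it does not show that either change would transfer to other cores, and it gives no explanation for the size of either step.

From the compounds shown here alone, whether chloro or fluoro in place of bromo would also give so large a step remains open. Also open, going by these compounds, is whether the lower number seen with 3-methylbut-2-en-1-yl would continue with a longer chain such as geranyl, with a saturated chain such as butyl, or with an ether chain ending in an amine or a carboxylic acid.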